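A Shared Change Applied to a Second Core

The source may report more compounds than this note shows. Statements on the series, on what has been measured and on what is new or still open speak of the compounds shown alone.

Three compounds have been measured so far:
compound 1, `O=C(Nc1ccc(Oc2ccnc3[nH]ccc23)cc1)c1cn(-c2ccc(C(F)(F)F)cc2Cl)c2ccccc2c1=O`, gives 2350 nM
compound 2, `O=C(Nc1ccc(Oc2ccnc3[nH]ccc23)cc1)c1cn(-c2ccc(F)c(Cl)c2)c2ccccc2c1=O`, gives 4810 nM
compound 3, `O=C(Nc1ccc(Oc2ccnc3[nH]ccc23)c(F)c1)c1cn(-c2ccc(C(F)(F)F)cc2Cl)c2ccccc2c1=O`, gives 1620 nM

All three were tested in a functional assay on A549 cells (Homo sapiens) for inhibition, read by MTT assay, with a stated time of 72 h; a higher number here means a weaker inhibitor, a lower number a stronger inhibitor. Compound 1 and compound 2 share one core and differ in a single place: 3-chloro-4-fluorophenyl in place of 2-chloro-4-(trifluoromethyl)phenyl on an aromatic nitrogen This change produced a 2.0-fold higher number from compound 1 to compound 2 (0.31 log units; beyond the scatter). Compound 3 stands on a second core, which differs from the core of compound 1 in one place: fluoro in place of hydrogen on an aromatic carbon That difference produced a 1.5-fold lower number from compound 1 to compound 3 (0.16 log units; within the scatter), so the two cores are close to each other in this assay.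

Compound 4, `O=C(Nc1ccc(Oc2ccnc3[nH]ccc23)c(F)c1)c1cn(-c2ccc(F)c(Cl)c2)c2ccccc2c1=O`, has not yet been measured. It is built on the core of compound 3 and differs from compound 3 in one place: 3-chloro-4-fluorophenyl in place of 2-chloro-4-(trifluoromethyl)phenyl on an aromatic nitrogen The surroundings of the place are described in the same words for both pairs, so this is the same change that was made from compound 1 to compound 2, now carried out on the second core. Going by the values given here, with only one earlier example of the change, the expectation for compound 4 rests on that single step and on the closeness of the two cores. Compound 4 is expected to show a 2.0-fold higher number from compound 3 to compound 4 (0.31 log units; beyond the scatter) because a 2.0-fold higher number from compound 1 to compound 2 (0.31 log units; beyond the scatter) was found for the same change. The estimate for compound 4 in this assay is 3300 nM, expected to fall between 1600 nM and 7000 nM.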

Compound 4, half-maximal inhibitory concentration: 2150 nM
Compound 4: the middle estimate sits 1.5-fold (0.19 log units) above what was measured; the measured number falls inside the stated range.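

In this assay, putting 3-chloro-4-fluorophenyl in place of 2-chloro-4-(trifluoromethyl)phenyl on the second core gives a 1.3-fold higher number from compound 3 to compound 4 (0.12 log units; within the scatter), and this step cannot be told apart from its counterpart on the first core: the same change on two cores in this assay, a 2.0-fold higher number (0.31 log units; beyond the scatter) from compound 1 to compound 2 and a 1.3-fold higher number (0.12 log units; within the scatter) from compound 3 to compound 4, 1.5-fold (0.19 log units) apart, within the scatter of two such steps. Read the other way round, fluoro in place of hydrogen on an aromatic carbon gives a 2.2-fold lower number from compound 2 to compound 4 (0.35 log units; beyond the scatter), and this step also agrees with its earlier counterpart: the same change on two cores in this assay, a 1.5-fold lower number (0.16 log units; within the scatter) from compound 1 to compound 3 and a 2.2-fold lower number (0.35 log units; beyond the scatter) from compound 2 to compound 4, 1.5-fold (0.19 log units) apart, within the scatter of two such steps. Across these four compounds, then, each change behaves about the same on both cores, but that rests on a single pair of steps per change between two closely related cores, so it does not show that the changes would carry over to other cores in the series.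

Still open, going by these compounds, is whether the agreement would hold if the fluoro were replaced by an amine or a carboxylic acid, or if a longer chain stood on the aromatic nitrogen in place of the aryl group. Also open, on these data alone, is whether steps of these sizes would appear in any measurement other than this assay.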